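A few compounds are considered here, and "the series" means these few. Any claim that something is new, unique, unknown or untested is made for them only; others in the source may bear on it.

The measured compounds, with their results in a functional assay on PC-3 cells (Homo sapiens) for cytotoxicity, read by MTT assay, with a stated time of 72 h; a lower number here means a stronger inhibitor, a higher number a weaker inhibitor:

Compound 1, `CNC(=O)c1cc(Oc2ccc(NC(=O)c3cc(-c4ccc(C)cc4)ncn3)cc2)ccn1`, gives > 100000 nM. For compound 1 this is a limit of the assay, not a number.
Compound 2, `CNC(=O)c1cc(Oc2ccc(NC(=O)c3cc(-c4ccc(C)cc4)ncn3)cc2F)ccn1`, gives 40200 nM.
Compound 3, `CNC(=O)c1cc(Oc2ccc(NC(=O)c3cc(-c4ccc(OC)cc4)ncn3)cc2F)ccn1`, gives 56200 nM.

Compound 2 and compound 3 share a core and differ in one place: methoxy in place of methyl on an aromatic carbon. This step, a 1.4-fold higher number from compound 2 to compound 3 (0.15 log units; within the scatter), is small enough to lie within the usual scatter of this assay, so the two values cannot be ordered against each other.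

Compound 2 and compound 1 differ in one place as well: hydrogen in place of fluoro on an aromatic carbon. Here the step is an at least 2.4-fold higher number from compound 2 to compound 1 (0.39 log units; beyond the scatter). Its size is known only as a lower bound because of the limit of > 100000 nM in this assay, at which 1 of the 3 values shown sits.

The unmeasured compound 4, `CNC(=O)c1cc(Oc2ccc(NC(=O)c3cc(-c4ccc(OC)cc4)ncn3)cc2)ccn1`, stands to compound 3 exactly as compound 1 stands to compound 2: hydrogen in place of fluoro on an aromatic carbon. The two changes are the same, and the surroundings of the place are described in the same words, so the same kind of weakening is expected in this assay. The step from compound 3 to compound 4 is expected to be a 2.7-fold higher number from compound 3 to compound 4 (0.43 log units; beyond the scatter), resting on the step of an at least 2.4-fold higher number from compound 2 to compound 1 (0.39 log units; beyond the scatter) seen on the neighbouring core. Since compound 3 starts from 56200 nM, a comparable step would carry compound 4 to a markedly higher number. Compound 4 is therefore estimated at 150000 nM, within a range from 60000 nM to 450000 nM.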

Compound 4, half-maximal inhibitory concentration: 38800 nM
Beside the measured number, compound 4's estimate is 3.9-fold (0.59 log units) above it; measured number outside the range, below it.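

In this assay, hydrogen in place of fluoro gives a 1.4-fold lower number from compound 3 to compound 4 (0.16 log units; within the scatter) and so does not repeat the clear rise in number seen on the core of compound 1, and the two steps differ: the same change on two cores in this assay, an at least 2.4-fold higher number (0.39 log units; beyond the scatter) from compound 2 to compound 1 and a 1.4-fold lower number (0.16 log units; within the scatter) from compound 3 to compound 4, at least 3.6-fold (0.55 log units) apart, beyond the scatter of two such steps.

The second change behaves the same way, since methoxy in place of methyl gives an at least 2.5-fold lower number from compound 1 to compound 4 (0.41 log units; beyond the scatter) and this does not match the step seen with the fluoro group present: the same change on two cores in this assay, a 1.4-fold higher number (0.15 log units; within the scatter) from compound 2 to compound 3 and an at least 2.5-fold lower number (0.41 log units; beyond the scatter) from compound 1 to compound 4, at least 3.6-fold (0.55 log units) apart, beyond the scatter of two such steps.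

Among these four compounds, then, neither change carries over from one core to the other as a step of fixed size, although two pairs cannot show why this is so or what either change would do on any further core.

Compound 1 gives > 100000 nM as a limit of the assay and not a number, which leaves its true value open. Also open, on these data alone, is what a chloro group in place of the fluoro, or an amine or a hydroxyl group in place of the methyl or methoxy, would do, with or without the fluoro present.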